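From Fluoro to Methoxy on a Shared Core

The compounds below may be only part of what the source reports. "The series", "measured", "known", "first", "only" and "open" are said of these compounds alone.

Three compounds built on one shared core have numbers in a functional assay on HaCaT cells (Homo sapiens) for inhibition, read by sulforhodamine B assay, with a stated time of 48 h; on this read-out lower numbers stand for stronger inhibition of growth and higher numbers for weaker inhibition of growth. Compound 1 `CC1(/C=C/c2ccc(F)cc2)C=CC(=O)O1` gives 47500 nM, the lowest of the three, which makes it the strongest growth inhibitor of this small set. Compound 3 `COc1cc(/C=C/C2(C)C=CC(=O)O2)cc(OC)c1OC` gives 175000 nM, and compound 2 `COc1ccc(/C=C/C2(C)C=CC(=O)O2)c(OC)c1OC` gives 217000 nM. Both numbers lie beyond the scatter from that of compound 1, while these two lie within the scatter of each other.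

The next compound to be tested is compound 4 `COc1ccc(/C=C/C2(C)C=CC(=O)O2)cc1`, which keeps the core of compound 1 and carries methoxy in place of fluoro on an aromatic carbon. Going by the values given here, no measured pair isolates this change, so the evidence for it is indirect. Compounds 2 and 3 both bear methoxy groups, but each also differs from compound 1 in more than one place. Compound 3 at 175000 nM still points toward a higher number for compound 4, although with a single methoxy group a smaller gap is expected. The expected step is a 2.3-fold higher number from compound 1 to compound 4 (0.36 log units; beyond the scatter), toward weaker inhibition of growth and only just beyond the scatter. For compound 4 the estimate is 110000 nM, with an expected range of 50000 nM to 220000 nM.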

Compound 4, concentration for total growth inhibition: 316000 nM
Compound 4: the middle estimate sits 2.9-fold (0.46 log units) below what was measured; measured number above the stated range.
By their numbers in this assay, from the lowest: compound 1; then compounds 3, 2 and 4 (each within the scatter of the next).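

Going by these compounds alone, compound 1 and compound 4 form the first pair here that differs in one place, so the exchange of fluoro for methoxy can now be read directly. In this assay the step is a 6.7-fold higher number from compound 1 to compound 4 (0.82 log units; beyond the scatter), toward weaker inhibition of growth. This shows that the number responds to the group on this aromatic carbon, para to a group of 9 heavy atoms, and that within this single pair fluoro gives the stronger inhibition of growth and methoxy the weaker, by a margin beyond the scatter. Nothing in the available evidence bears on what lies behind this step.

With only fluoro and methoxy compared directly at this position, the compounds shown leave open where a hydrogen, a chloro group or a hydroxyl group on the same aromatic carbon would fall in this assay relative to this pair. They also leave open whether an amine, a carboxylic acid or a longer chain such as ethoxy there would give a number nearer that of compound 1 or nearer that of compound 4.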